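From an inactive methoxyphenyl ether to a bromophenyl analogue

A few compounds are considered here, and "the series" means these few. Any claim that something is new, unique, unknown or untested is made for them only; others in the source may bear on it.

In an in vitro assay on cells for inhibition of Amine oxidase [flavin-containing] A (Homo sapiens), read by coupled enzyme assay, with a stated time of 20 min (on this read-out higher numbers stand for weaker inhibition and lower numbers for stronger inhibition), compound 1 `COc1cccc(OCc2nc3c(c(=O)n(C)c(=O)n3C)n2C)c1` is recorded as "not active" (no number reported), so no single number places it on the scale. In this assay compound 2 `Cn1c(=O)c2c(nc(CCSc3ccc(Cl)cc3)n2C)n(C)c1=O` gives 142000 nM, a weak result. Compound 3 `Cn1c(=O)c2c(nc(COc3ccc(Br)cc3)n2C)n(C)c1=O` has not been tested. It differs from compound 1 in one place: 4-bromophenyl in place of 3-methoxyphenyl on an oxygen on a saturated carbon. Among the compounds with values here, no step between measured compounds matches this change, and the only number at hand comes from compound 2, which is a different ether. Compound 1 gives no number at all, so no direction can be read from it. The change from compound 1 to compound 3 is therefore expected to move, if anywhere, only within the usual scatter and to stay in the weak range. For compound 3 the half-maximal inhibitory concentration in this assay is estimated at 150000 nM, within a range from 40000 nM to 600000 nM, with a fair chance that only a limit is reported.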

Compound 3, half-maximal inhibitory concentration: 10700 nM
For compound 3 the middle estimate is 14-fold (1.15 log units) above the measured one; the whole stated range lies above it.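

No step can be read from compound 1 to compound 3: in this assay compound 1 gives "not active" (no number reported) and compound 3 gives 10700 nM. No evidence bears on this result. The compounds shown leave open how 4-bromophenyl and 3-methoxyphenyl compare on this read-out.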